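Aryl Triazole Esters of a Triterpenoid Core Against Prostate Cancer Cells

The source may hold more compounds than are shown below. What is called first, only, known or untested is meant among the compounds shown, and "the series" means these compounds.

The series shares a triterpenoid core carried on a triazole ester. Compound 1 `COc1ccccc1-n1cc(COC(=O)/C(C)=C/CC/C(C)=C/CC/C(C)=C/CC[C@@H]2[C@@]3(C)CCC(=O)C(C)(C)[C@H]3CC[C@@]2(C)O)nn1` bears a 2-methoxyphenyl group on the triazole nitrogen; in a functional assay on DU-145 cells (Homo sapiens) for antiproliferative activity, read by MTT assay, with a stated time of 48 h (on this read-out higher numbers stand for weaker inhibition and lower numbers for stronger inhibition), compound 1 gives only the limit of > 150000 nM. Compound 2 `C/C(=C\CC/C(C)=C/CC[C@@H]1[C@@]2(C)CCC(=O)C(C)(C)[C@H]2CC[C@@]1(C)O)CC/C=C(\C)C(=O)OCc1cn(-c2ccc(F)c(Cl)c2)nn1` carries a 3-chloro-4-fluorophenyl group in its place. In this assay compound 2 likewise gives only the limit of > 150000 nM, so the step that the two limits leave unreadable from compound 1 to compound 2 cannot be read. Compound 3 `C#CCOC(=O)/C(C)=C/CC/C(C)=C/CC/C(C)=C/CC[C@@H]1[C@@]2(C)CCC(=O)C(C)(C)[C@H]2CC[C@@]1(C)O`, with a propargyl ester instead of the triazole arm, gives 46100 nM in this assay. Compound 2 thus stands at the limit, as the evidence shows (the limit of > 150000 nM in this assay, at which 2 of the 3 values shown sit).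

Compound 4 `C/C(=C\CC/C(C)=C/CC[C@@H]1[C@@]2(C)CCC(=O)C(C)(C)[C@H]2CC[C@@]1(C)O)CC/C=C(\C)C(=O)OCc1cn(-c2ccccc2)nn1` differs from compound 2 by phenyl in place of 3-chloro-4-fluorophenyl on an aromatic nitrogen. Among the measured compounds shown here, no readable step bears on this change, since the only measured exchange on the aromatic nitrogen is masked by two limits. Compound 4 is therefore expected to sit near the limit as well, with the step of a number no higher from compound 2 to compound 4 (the limit leaves the size open) estimated as small. Compound 4 is estimated at 150000 nM, within 60000 nM to 300000 nM.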

Compound 4, half-maximal inhibitory concentration: 95500 nM
Estimate against measurement, compound 4: 1.6-fold (0.20 log units) above; the range from low to high includes it.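

With phenyl on the aromatic nitrogen, the aryl triazole arm gives its first number rather than a limit in this assay. The exchange on the aromatic nitrogen now shows an at least 1.5-fold lower number from compound 2 to compound 4 (0.19 log units; that floor lies within the scatter), and the exchange of methoxy for hydrogen shows an at least 1.5-fold lower number from compound 1 to compound 4 (0.19 log units; that floor lies within the scatter), so neither floor establishes a real difference on its own. The exchange of ethynyl for 1-phenyl-1H-1,2,3-triazol-4-yl, unreadable until now for any aryl triazole, shows a 2.1-fold higher number from compound 3 to compound 4 (0.32 log units; beyond the scatter).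

Compound 2 remains a limit and not a number: the limit of > 150000 nM in this assay, at which 2 of the 4 values shown sit.

The compounds shown leave open whether a methyl, a benzyl or an aminophenyl group on the aromatic nitrogen would bring the number closer to that of compound 3. The contributions of the chlorine and the fluorine of compound 2 also remain unseparated.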